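This account rests on a few compounds, and the source may have more. Where it says the series, first, only, none or still open, it means among the compounds named here.

Of the compounds shown here, two built on a shared core have so far been read in a functional assay on MCF7 cells (Homo sapiens) for inhibition, read by CCK-8 assay, with a stated time of 48 h; on this read-out higher numbers stand for weaker inhibition of growth and lower numbers for stronger inhibition of growth. In this assay compound 1 `Cc1ccc(CNc2nc(Nc3ccc(N4CCN(C)CC4)cn3)ncc2Cl)cc1` gives 38100 nM, and compound 2 `COc1cccc(CNc2nc(Nc3ccc(N4CCN(C)CC4)cn3)ncc2Cl)c1` gives 19500 nM. These two values stand within the usual scatter of each other, so neither compound can be ranked ahead of the other. Compound 3 `COc1ccccc1CNc1nc(Nc2ccc(N3CCN(C)CC3)cn2)ncc1Cl` has not yet been measured. Its difference from compound 2 is 2-methoxyphenyl in place of 3-methoxyphenyl on a saturated chain carbon bound to a nitrogen on an aromatic ring. In words, 2-methoxyphenyl stands in place of 3-methoxyphenyl on a saturated chain carbon bound to a nitrogen on an aromatic ring. Going by the values given here, only one measured step bears on this place, namely a 2.0-fold lower number from compound 1 to compound 2 (0.29 log units; within the scatter), where 3-methoxyphenyl replaced 4-methylphenyl. Among the compounds with values here, no measured compound carries 2-methoxyphenyl, so the data hold no direct precedent for this group. On that slender evidence, no step beyond the scatter is expected in this assay, in either direction. The expected step is a 1.0-fold higher number from compound 2 to compound 3 (0.01 log units; within the scatter). The estimate for compound 3 is 20000 nM, with the measurement expected to fall between 8000 nM and 50000 nM.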

Compound 3, concentration for 50% growth inhibition: > 100000 nM
Compound 3 ended at the assay's limit; the forecaster's own chance of this, stated with the estimate: 8%; middle value at least 5.0-fold (0.69 log units) from the limit.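

In this assay compound 3 gives > 100000 nM, which is a limit of the assay and not a number: the limit of > 100000 nM in this assay, at which 1 of the 3 values shown sits.

With the same atoms joined differently, 2-methoxyphenyl in place of 3-methoxyphenyl gives an at least 5.1-fold higher number from compound 2 to compound 3 (0.70 log units; beyond the scatter), so the group on the saturated chain carbon bound to a nitrogen on an aromatic ring can change the read-out beyond the scatter, which a 2.0-fold lower number from compound 1 to compound 2 (0.29 log units; within the scatter) did not show. Set against the 4-methylphenyl group, 2-methoxyphenyl gives an at least 2.6-fold higher number from compound 1 to compound 3 (0.41 log units; beyond the scatter), so compound 3 shows weaker inhibition of growth than both earlier compounds, and both steps are bounds rather than exact sizes.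

From the compounds shown here alone, the true size of these steps stays open, since the value for compound 3 gives only a limit. Also open, going by these compounds, is whether the change follows the methoxy group itself or would recur with 2-methylphenyl, 2-chlorophenyl or 2-hydroxyphenyl at this place, and how 4-methoxyphenyl would compare with 3-methoxyphenyl.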